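This account rests on a few compounds, and the source may have more. Where it says the series, first, only, none or still open, it means among the compounds named here.

Measured so far in an ADME assay on microsomes from liver (Mus musculus) for metabolic stability, with a stated time of 30 min; on this read-out lower numbers stand for a less stable compound and higher numbers for a more stable compound:
Compound 1 `COCC(=O)NC1CCN(c2nc(C)c3cc(NC(=O)/C=C/c4ccc(OC(F)(F)F)cc4)ccc3n2)CC1` gives 57%.
Compound 2 `Cc1nc(NCCCNS(C)(=O)=O)nc2ccc(NC(=O)/C=C/c3ccc(OC(F)(F)F)cc3)cc12` gives 58%.
Compound 3 `Cc1nc(N2CCC(N3CCCS3(=O)=O)CC2)nc2ccc(NC(=O)/C=C/c3ccc(OC(F)(F)F)cc3)cc12` gives 83%.

Compound 3 stands highest of the three; its gaps to compound 2 and to compound 1 both lie beyond the scatter, so it is the most stable compound measured here. Compound 1 and compound 2 lie within the scatter of each other.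

Compound 4 `Cc1nc(N2CCC(N3CCCC3=O)CC2)nc2ccc(NC(=O)/C=C/c3ccc(OC(F)(F)F)cc3)cc12` has not been measured. It differs from compound 3 in one place: a group of 6 heavy atoms (4 carbon, 1 nitrogen, 1 oxygen; one five-membered non-aromatic ring with 1 hetero atom) in place of a group of 7 heavy atoms (3 carbon, 1 nitrogen, 2 oxygen, 1 sulfur; one five-membered non-aromatic ring with 2 hetero atoms), on a saturated ring carbon.

Among the measured compounds shown here, two measured steps bear on this. The step of a number 26 percentage points higher from compound 1 to compound 3 (beyond the scatter) changed the group on this same saturated ring carbon, and the gain came with the very group that now leaves. The step of a number 1 percentage points higher from compound 1 to compound 2 (within the scatter) exchanged a different group and stayed within the scatter. For the measured compounds named here, no measured step shows this exact exchange. Because the gain in a number 26 percentage points higher from compound 1 to compound 3 (beyond the scatter) belonged to the leaving group, part of it is expected to be lost, a modest drop a number 13 percentage points lower from compound 3 to compound 4 (beyond the scatter). Compound 4 is therefore expected at 70%, in the range 52% to 88%.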

Compound 4, percent of the compound remaining: 85%
Compound 4: middle estimate off by 15 percentage points, on the low side, within the range that was stated.
By their numbers in this assay, from the lowest: compounds 1 and 2 (each within the scatter of the next); then compounds 3 and 4 (each within the scatter of the next).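

In this assay, 2-oxopyrrolidin-1-yl on the saturated ring carbon and the sulfur-containing five-membered ring it replaces cannot be told apart, with a number 2 percentage points higher from compound 3 to compound 4 (within the scatter), so the high number does not depend on that sulfur-containing ring. The advantage over the open-chain groups also appears with this sulfur-free ring: a number 28 percentage points higher from compound 1 to compound 4 (beyond the scatter) at the same carbon, and a number 27 percentage points higher from compound 2 to compound 4 (beyond the scatter) when the whole group on the aromatic carbon is exchanged. No measurement shown gives a reason for these steps.

Going by these compounds, how a six-membered piperidin-2-one ring or a simple primary amine would fare on this saturated ring carbon stays open. So does the part played by the carbonyl of 2-oxopyrrolidin-1-yl, which a plain pyrrolidin-1-yl ring at the same place would help to show.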